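The compounds below may be only part of what the source reports. "The series", "measured", "known", "first", "only" and "open" are said of these compounds alone.

Measured in a functional assay on HepG2 cells (Homo sapiens) for cytotoxicity, read by MTT assay, with a stated time of 24 h; a lower number here means a stronger inhibitor, a higher number a weaker inhibitor:
compound 1 `Cc1ccccc1COc1n[nH]c(=S)n1/N=C/c1c[nH]nc1-c1ccc(Cl)cc1` gives 44 ug/mL
compound 2 `Cc1ccc(COc2n[nH]c(=S)n2/N=C/c2c[nH]nc2-c2ccc(Cl)cc2)cc1` gives 28 ug/mL
compound 3 `Cc1ccccc1COc1n[nH]c(=S)n1/N=C/c1c[nH]nc1-c1ccc(F)cc1` gives 48 ug/mL

Compound 4 `Cc1ccc(COc2n[nH]c(=S)n2/N=C/c2c[nH]nc2-c2ccc(F)cc2)cc1` awaits measurement in this assay. Compound 4 differs from compound 3 by 4-methylphenyl in place of 2-methylphenyl on a saturated chain carbon bound to an oxygen on an aromatic ring. The same change, (4-methylphenyl in place of 2-methylphenyl on a saturated chain carbon bound to an oxygen on an aromatic ring), has been measured once, on the core of compound 1, where it gave a 1.6-fold lower number from compound 1 to compound 2 (0.20 log units; within the scatter). The cores of the two pairs differ by fluoro in place of chloro on an aromatic carbon, a change that itself gave a 1.1-fold higher number from compound 1 to compound 3 (0.04 log units; within the scatter). The place of the change is described in the same words in both pairs, so the change counts as the same. With a single measured example to go on, the step from compound 3 to compound 4 is expected to be a 1.6-fold lower number from compound 3 to compound 4 (0.20 log units; within the scatter), resting on the earlier step of a 1.6-fold lower number from compound 1 to compound 2 (0.20 log units; within the scatter). Compound 4 is therefore expected to give 30 ug/mL in this assay, with a range from 18 ug/mL to 50 ug/mL.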

Compound 4, half-maximal inhibitory concentration: 45 ug/mL
Compound 4: middle estimate off by 1.5-fold (0.18 log units), on the low side, and the stated range covers the measured number.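

In this assay the change from 2-methylphenyl to 4-methylphenyl gives a 1.1-fold lower number from compound 3 to compound 4 (0.03 log units; within the scatter), and its two steps on the two cores agree within the scatter: the same change on two cores in this assay, a 1.6-fold lower number (0.20 log units; within the scatter) from compound 1 to compound 2 and a 1.1-fold lower number (0.03 log units; within the scatter) from compound 3 to compound 4, 1.5-fold (0.17 log units) apart, within the scatter of two such steps.
The change to fluoro from chloro, read in the other direction as chloro to fluoro on the 4-methylphenyl compounds, gives a 1.6-fold higher number from compound 2 to compound 4 (0.21 log units; within the scatter) and also agrees with its earlier step: the same change on two cores in this assay, a 1.1-fold higher number (0.04 log units; within the scatter) from compound 1 to compound 3 and a 1.6-fold higher number (0.21 log units; within the scatter) from compound 2 to compound 4, 1.5-fold (0.17 log units) apart, within the scatter of two such steps.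
Each step lies within the scatter, so these two changes carry between the two cores without a detectable difference, but this does not show that either change has a real effect on the number, nor that the agreement extends beyond these compounds.

Open, on these data alone, is whether a methoxy group or a carboxylic acid on the phenyl ring, or a longer chain in place of the saturated chain carbon, would give a step beyond the scatter.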